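A few compounds are considered here, and "the series" means these few. Any claim that something is new, unique, unknown or untested is made for them only; others in the source may bear on it.

Three compounds here share one core and differ only in the group carried on the aromatic carbon of the anilide. Compound 1 `Cc1nc(-c2cccc(NC(=O)C3CCCN(C(=O)c4cc(C(F)(F)F)cc(C(F)(F)F)c4)C3)c2)cs1` gives 1% in an ADME assay on PC-3 cells (Homo sapiens) for cytotoxicity, read by WST assay, tested at 100 uM; a higher number here means more inhibition at the concentration tested (going by the name of the read-out), a lower number less inhibition. Compound 2 `O=C(Nc1cccc(OCCc2ccccn2)c1)C1CCCN(C(=O)c2cc(C(F)(F)F)cc(C(F)(F)F)c2)C1` gives 5% in this assay, and compound 3 `O=C(Nc1cccc(-c2cnco2)c1)C1CCCN(C(=O)c2cc(C(F)(F)F)cc(C(F)(F)F)c2)C1` gives 9% in this assay. Compound 3 sits with both others inside the usual scatter: a number 8 percentage points higher from compound 1 to compound 3 (within the scatter), and a number 4 percentage points higher from compound 2 to compound 3 (within the scatter). Compound 4 `O=C(Nc1cccc(CN2CCCC2)c1)C1CCCN(C(=O)c2cc(C(F)(F)F)cc(C(F)(F)F)c2)C1` is reached from compound 3 by (pyrrolidin-1-yl)methyl in place of 1,3-oxazol-5-yl on an aromatic carbon. The exchanges already measured at this carbon, from compound 1 and from compound 2 to compound 3, moved this assay only within the scatter, so a step of a number 2 percentage points lower from compound 3 to compound 4 (within the scatter) is expected, none beyond the scatter. Compound 4 is therefore estimated at 7%, within 0% to 20%.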

Compound 4, a percentage reported as inhibition, at one concentration (the size of the read-out at that concentration, not a potency): 51%
The estimate for compound 4 lay 44 percentage points below the measured number; measured number above the stated range.
By their numbers in this assay, from the lowest: compounds 1, 2 and 3 (each within the scatter of the next); then compound 4.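

In this assay this aromatic carbon no longer looks indifferent to its substituent: (pyrrolidin-1-yl)methyl gives a number 42 percentage points higher from compound 3 to compound 4 (beyond the scatter) and a number 46 percentage points higher from compound 2 to compound 4 (beyond the scatter) and also a number 50 percentage points higher from compound 1 to compound 4 (beyond the scatter) while the three earlier groups stayed within the scatter of one another. Unlike the 1,3-oxazol-5-yl it replaces, the entering group carries a five-membered non-aromatic ring. Nothing available explains this rise. As far as these compounds go, whether it follows the pyrrolidine ring itself remains open, as a piperidine, a morpholine or an open-chain dimethylamine on the same methyl link could show. From the compounds shown here alone, whether a longer chain to the ring would keep the rise is equally open.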